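Replacing the sulfur-linked heteroaryl of compound 1 with a piperazinyl

The compounds below may be only part of what the source reports. "The series", "measured", "known", "first", "only" and "open" are said of these compounds alone.

Measured so far:
compound 1 `Cc1ccc2oc(SCC(=O)Nc3ccc(-c4nc(-c5ccccc5)c(-c5ccccc5)n4C)cc3)nc2c1`: 69.8%
compound 2 `Cn1c(-c2ccc(NC(=O)CSc3nc4ccccc4s3)cc2)nc(-c2ccccc2)c1-c1ccccc1`: 82.7%
compound 3 `Cn1nnnc1SCC(=O)Nc1ccc(-c2nc(-c3ccccc3)c(-c3ccccc3)n2C)cc1`: 89%

In a functional assay on HT-29 cells (Homo sapiens) for cytotoxicity, read by MTT assay, with a stated time of 24 h, tested at 80 ug/mL (on this read-out higher numbers stand for a stronger effect at the one concentration tested and lower numbers for a weaker effect), compound 1 stands lowest of the three numbers. Its two neighbours both lie higher: a number 12.9 percentage points higher from compound 1 to compound 2 (beyond the scatter) and a number 19.2 percentage points higher from compound 1 to compound 3 (beyond the scatter), each beyond the scatter, while a number 6.3 percentage points higher from compound 2 to compound 3 (within the scatter) stays within it. Both measured steps from compound 1 kept a sulfur on the chain carbon and exchanged only the heteroaryl on it.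

Compound 4 `CN(C)/C=C/N1CCN(CC(=O)Nc2ccc(-c3nc(-c4ccccc4)c(-c4ccccc4)n3C)cc2)CC1` departs further. Its difference from compound 1 is 4-(2-(dimethylamino)ethenyl)piperazin-1-yl in place of (5-methyl-1,3-benzoxazol-2-yl)sulfanyl on a saturated chain carbon bound to a carbonyl carbon. Within the data shown here, no measured step exchanges the sulfur-linked part for a nitrogen-linked ring, so neither step bears directly on this change; they show only that moving away from the 5-methyl-1,3-benzoxazol-2-yl of compound 1 has so far given higher numbers in this assay, by modest amounts. With nothing closer to rest on, a step from compound 1 to compound 4 of uncertain direction is expected, most likely small and within the scatter, with a wide range: a number 2.2 percentage points higher from compound 1 to compound 4 (within the scatter) is the estimate. For compound 4 the expected value in this assay is therefore 72%, between 45% and 95%.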

Compound 4, a percentage reported as activity, at one concentration (the size of the read-out at that concentration, not a potency): 45.4%
Compound 4: the middle estimate sits 26.6 percentage points above what was measured; the range from low to high includes it.
By their numbers in this assay, from the lowest: compound 4; then compound 1; then compounds 2 and 3 (each within the scatter of the next).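

In this assay the saturated chain carbon bound to a carbonyl carbon now shows what exchanging the whole sulfur-linked part does, and the steps to the piperazine all run downward: a number 24.4 percentage points lower from compound 1 to compound 4 (beyond the scatter) and a number 37.3 percentage points lower from compound 2 to compound 4 (beyond the scatter) and a number 43.6 percentage points lower from compound 3 to compound 4 (beyond the scatter) in this series. Earlier steps only swapped the heteroaryl on sulfur, whereas here the number falls with each of the three sulfur-linked groups as the starting point, and the fall is largest from the two compounds with the higher numbers. The group leaving compound 1 and the group entering compound 4 match in heavy atoms and hydrogen-bond acceptors, so those counts do not separate them, and no measurement at hand gives a reason for the fall.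

Still open, going by these compounds, is whether the lower number belongs to the piperazine ring, to the 2-(dimethylamino)ethenyl on it, or to the loss of the sulfur link itself. An unsubstituted piperazin-1-yl, a morpholin-4-yl on the same chain carbon, or a 4-methylpiperazin-1-yl would help to tell these apart.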